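Swapping 3,4-dimethylphenyl for 3-methoxyphenyl on the amine nitrogen

The source may report more compounds than this note shows. Statements on the series, on what has been measured and on what is new or still open speak of the compounds shown alone.

In a functional assay on HeLa cells (Homo sapiens) for inhibition, read by sulforhodamine B assay (a lower number here means a stronger inhibitor, a higher number a weaker inhibitor), compound 3 (`Cc1ccc(NC2=CC(=O)c3nc4n(c3C2=O)[C@H]2OC[C@@H](O)[C@H]2OC4)cc1C`) gives 2690 nM as its reading. Compound 1 (`CCc1ccc(NC2=CC(=O)c3nc4n(c3C2=O)[C@H]2OC[C@@H](O)[C@H]2OC4)cc1`) gives 3990 nM as its reading, which lies within the scatter of compound 3. Compound 2 (`O=C1C=C(Nc2ccc(C(F)(F)F)cc2)C(=O)c2c1nc1n2[C@H]2OC[C@@H](O)[C@H]2OC1`) returns only a limit of the assay, > 8000 nM and no number. Compound 3 is separated from that limit by an at least 2.9-fold lower number from compound 2 to compound 3 (0.47 log units; beyond the scatter) and no more can be said of the gap.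

Compound 4 (`COc1cccc(NC2=CC(=O)c3nc4n(c3C2=O)[C@H]2OC[C@@H](O)[C@H]2OC4)c1`) differs from compound 3 in one place: 3-methoxyphenyl in place of 3,4-dimethylphenyl on an amine nitrogen. Within the data shown here, no measured step makes this exact exchange, but two measured steps change the group at this same place. Among the measured compounds shown here, the one between the two compounds with numbers was small (a 1.5-fold lower number from compound 1 to compound 3 (0.17 log units; within the scatter)) and so a large shift is not expected here, although the step from compound 2 shows that this place can matter. The expected size is a 1.3-fold higher number from compound 3 to compound 4 (0.11 log units; within the scatter) and this estimate implies no change beyond the scatter. For compound 4 the estimated value is 3500 nM within an expected range from 1500 nM to 8000 nM in this assay overall.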

Compound 4, half-maximal inhibitory concentration: 4280 nM
Beside the measured number, compound 4's estimate is 1.2-fold (0.09 log units) below it, within the range that was stated.
By their numbers in this assay, from the lowest: compounds 3, 1 and 4 (each within the scatter of the next). At a limit, above all of these: compound 2.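

In this assay, 3-methoxyphenyl in place of 3,4-dimethylphenyl on the amine nitrogen gives a 1.6-fold higher number from compound 3 to compound 4 (0.20 log units; within the scatter), and in place of 4-ethylphenyl it gives a 1.1-fold higher number from compound 1 to compound 4 (0.03 log units; within the scatter). Compound 4 thus adds an oxygen and a hydrogen-bond acceptor to this group, yet the three compounds with numbers cannot be told apart in this assay. The step of an at least 1.8-fold lower number from compound 2 to compound 4 (0.27 log units; that floor lies within the scatter) does not clearly separate the pair, whereas the step of an at least 2.9-fold lower number from compound 2 to compound 3 (0.47 log units; beyond the scatter) does, and the reading of compound 2 is a limit of the assay, not a number: the limit of > 8000 nM in this assay, at which 1 of the 4 values shown sits.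

The compounds shown leave open whether a reading beyond the scatter of these three could come from another group on the amine nitrogen, such as a pyridine ring, a carboxylic acid on the phenyl ring or a plain alkyl chain. They also leave open how far below the limit any such reading might fall.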